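The source may report more compounds than this note shows. Statements on the series, on what has been measured and on what is new or still open speak of the compounds shown alone.

Compound 3 `C[C@@H](Cn1ccc(-c2ccc(C#N)c(Cl)c2)n1)NC(=O)C1CC(=O)C1` gives 3040 nM in a functional assay on LNCaP cells (Homo sapiens) for antiproliferative activity, read by CCK-8 assay, with a stated time of 6 days; on this read-out lower numbers stand for stronger inhibition and higher numbers for weaker inhibition. Among the three measured compounds its number is the highest, yet both gaps stay within the scatter: compound 1 `CC(O)c1cccc(C(=O)N[C@@H](C)Cn2ccc(-c3ccc(C#N)c(Cl)c3)n2)c1` gives 2280 nM, and a 1.3-fold higher number from compound 1 to compound 3 (0.12 log units; within the scatter); compound 2 `C[C@@H](Cn1ccc(-c2ccc(C#N)c(Cl)c2)n1)NC(=O)c1ccccc1F` gives 1810 nM, and a 1.7-fold higher number from compound 2 to compound 3 (0.23 log units; within the scatter). The remaining pair behaves the same way, since a 1.3-fold lower number from compound 1 to compound 2 (0.10 log units; within the scatter).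

Compound 4 `C[C@@H](Cn1ccc(-c2ccc(C#N)c(Cl)c2)n1)NS(=O)(=O)c1cccnc1` differs from compound 3 in one place: (pyridin-3-yl)sulfonyl in place of (3-oxocyclobutyl)carbonyl on an amine nitrogen. For the measured compounds named here, no measured step exchanges a carbonyl for a sulfonyl, so the three steps bear on it only indirectly; what they do show is that three quite different substituents on that carbonyl carbon all land within the scatter of one another in this assay. On that basis the expected step of a 1.2-fold lower number from compound 3 to compound 4 (0.08 log units; within the scatter) is no step beyond the scatter, in neither direction. Compound 4 is therefore estimated at 2500 nM, with a range from 900 nM to 7000 nM in this assay.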

Compound 4, half-maximal inhibitory concentration: 6140 nM
The estimate for compound 4 lay 2.5-fold (0.39 log units) below the measured number; the range from low to high includes it.
By their numbers in this assay, from the lowest: compounds 2, 1 and 3 (each within the scatter of the next); then compound 4.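

For the compounds shown here, on the amine nitrogen, exchanging a carbonyl-linked group for (pyridin-3-yl)sulfonyl is the first change here to leave the scatter in this assay (a 2.0-fold higher number from compound 3 to compound 4 (0.31 log units; beyond the scatter)), and the step from the fluorinated amide points the same way (a 3.4-fold higher number from compound 2 to compound 4 (0.53 log units; beyond the scatter)). The groups on the carbonyl carbon had stayed within the scatter of one another, so this result shows that the series does respond at this position, though only modestly and towards weaker inhibition. No evidence is available to explain this shift.

Going by these compounds, the sulfonyl and the pyridine ring enter together, so their separate shares in these steps remain unknown. A pyridin-3-yl group on a carbonyl carbon, or a 2-fluorophenyl or methyl group on a sulfonyl, would be needed to separate them.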